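A Demethylation Step Tested Against Two Assay Limits

A few compounds are considered here, and "the series" means these few. Any claim that something is new, unique, unknown or untested is made for them only; others in the source may bear on it.

Three ureas of one shared core were measured in a functional assay on DU-145 cells (Homo sapiens) for inhibition, read by sulforhodamine B assay, with a stated time of 48 h; on this read-out lower numbers stand for stronger inhibition of growth and higher numbers for weaker inhibition of growth: compound 1 `O=C(Nc1cccc(-n2cc(-c3ccncc3)c(-c3ccc(Cl)c(O)c3)n2)c1)Nc1cccc(C(F)(F)F)c1`, compound 2 `COc1cc(-c2nn(-c3cccc(NC(=O)Nc4cccc(C(F)(F)F)c4)c3)cc2-c2ccncc2)ccc1Cl` and compound 3 `COc1cc(-c2nn(-c3cccc(NC(=O)Nc4ccc(Cl)c(C(F)(F)F)c4)c3)cc2-c2ccncc2)ccc1Cl`. In this assay compound 1 reached only the limit > 32500 nM. Compound 2 likewise gave only the limit > 50000 nM. Compound 3 also stopped at the limit > 32500 nM.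

The change hydrogen in place of methyl on an oxygen on an aromatic ring gave a step that the two limits leave unreadable from compound 2 to compound 1, and the change chloro in place of hydrogen on an aromatic carbon gave a step that the two limits leave unreadable from compound 2 to compound 3; both steps are hidden between the limit of > 32500 nM in this assay, at which 2 of the 3 values shown sit, and (the limit of > 50000 nM in this assay, at which 1 of the 3 values shown sits).

Compound 4 `O=C(Nc1cccc(-n2cc(-c3ccncc3)c(-c3ccc(Cl)c(O)c3)n2)c1)Nc1ccc(Cl)c(C(F)(F)F)c1` is not yet measured. It differs from compound 3 by hydrogen in place of methyl on an oxygen on an aromatic ring, the same change as from compound 2 to compound 1, made at a place described in identical words; the two cores differ by chloro in place of hydrogen on an aromatic carbon.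

Since the earlier instance of this change left no readable step, the expected step is a step that the limit leaves unreadable from compound 3 to compound 4, resting on the fact that compound 2 and compound 1 both sat at limits. Compound 4 is therefore estimated at 40000 nM, with a range from 15000 nM to 100000 nM, and most likely this assay again reports only a limit.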

Compound 4, concentration for total growth inhibition: 4630 nM
For compound 4 the middle estimate is 8.6-fold (0.94 log units) above the measured one; the whole stated range lies above it.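

In this assay, among these compounds, methoxy to hydroxy on the core that carries the added chloro gave an at least 7.0-fold lower number from compound 3 to compound 4 (0.84 log units; beyond the scatter), and compound 4 gives 4630 nM, the only value among the four that is not a limit. Keeping the hydroxy and adding the chloro gave an at least 7.0-fold lower number from compound 1 to compound 4 (0.84 log units; beyond the scatter), so the change reads clearly in one core and only in the presence of that chloro, and the two steps together single out compound 4 alone. They do not show that the change carries over from one core to the other, as the earlier instance and the step from compound 2 to compound 3 cannot be read, and no size can be compared: the limit of > 32500 nM in this assay, at which 2 of the 4 values shown sit.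

The compounds shown leave open whether the gain belongs to the hydroxy itself, or whether an amine, a carboxylic acid or a longer chain such as ethoxy in its place would read the same way. They also leave open whether bromo in place of the added chloro would give a readable value.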